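The source may report more compounds than this note shows. Statements on the series, on what has been measured and on what is new or still open speak of the compounds shown alone.

Measured compounds, values in an assay on isolated protein for agonist activity at Toll-like receptor 8 (Homo sapiens); a higher number here means that more compound is needed for the effect, a lower number that less compound is needed:
compound 1 `CCC[C@H](CCO)Nc1nc(N)nnc1OCc1nccc(OC)c1OC`: 560 nM
compound 2 `CCCCNc1nc(N)nnc1OC`: 2040 nM
compound 3 `CCCCNc1nc(N)nnc1OC(C)C`: 460 nM

Compound 2 stands highest of the three numbers in this assay, above compound 1 and compound 3 by steps beyond the scatter. Compound 4 `CCCCNc1nc(N)nnc1OCc1cccnc1` differs from compound 2 by pyridin-3-yl in place of hydrogen on a saturated chain carbon bound to an oxygen on an aromatic ring, so the ether grows much as it does in compound 1 and compound 3. Within the data shown here, the only step of that kind among measured compounds is a 4.4-fold lower number from compound 2 to compound 3 (0.65 log units; beyond the scatter), and compound 1 with its larger ether also shows a lower number than compound 2. A modest downward step in this assay is therefore expected, given a 4.4-fold lower number from compound 2 to compound 3 (0.65 log units; beyond the scatter); the estimate for compound 4 is 450 nM, range 150 nM to 1400 nM, which would mean a 4.5-fold lower number from compound 2 to compound 4 (0.66 log units; beyond the scatter).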

Compound 4, half-maximal effective concentration: 590 nM
Estimate against measurement, compound 4: 1.3-fold (0.12 log units) below; the measured number falls inside the stated range.
By their numbers in this assay, from the lowest: compounds 3, 1 and 4 (each within the scatter of the next); then compound 2.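

In this assay, pyridin-3-yl in place of hydrogen on a saturated chain carbon bound to an oxygen on an aromatic ring gives a 3.5-fold lower number from compound 2 to compound 4 (0.54 log units; beyond the scatter). The downward step from compound 2 at this ether is therefore not confined to isopropyl, as seen in a 4.4-fold lower number from compound 2 to compound 3 (0.65 log units; beyond the scatter), and it also occurs with an aromatic ring in the ether. No supporting data are available to account for either step. Still open, from the compounds shown here alone, is whether phenyl or pyridin-2-yl at the same place would give a step of similar size.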